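This account rests on a few compounds, and the source may have more. Where it says the series, first, only, none or still open, it means among the compounds named here.

Compound 3 `O=C(O)c1ccc(C(=O)/C(=C\c2ccc(Br)c([N+](=O)[O-])c2)SCc2ccc(Cl)cc2)cc1` stands at a limit in a functional assay on DU-145 cells (Homo sapiens) for inhibition, read by trypan blue exclusion, with a stated time of 96 h (on this read-out higher numbers stand for weaker inhibition of growth and lower numbers for stronger inhibition of growth), where compound 3 gives < 1000 nM. Compound 1 `O=C(O)c1ccc(/C=C(/SCc2ccc(Cl)cc2)C(=O)c2ccc(C(=O)O)cc2)cc1` also stands at a limit: in this assay compound 1 gives > 100000 nM. Compound 2 `CN(C)c1ccc(/C=C(/SCc2ccc(Cl)cc2)C(=O)c2ccc(Cl)cc2)cc1` stands at a limit as well; in this assay compound 2 gives > 100000 nM. Two of the three values thus sit at the limit of > 100000 nM in this assay, at which 2 of the 3 values shown sit, and one at the limit of < 1000 nM in this assay, at which 1 of the 3 values shown sits, so compound 3 can only be placed at the strong end of what was measured. Compound 4 `CN(C)c1ccc(/C=C(/SCc2ccc(Cl)cc2)C(=O)c2ccc(C(=O)O)cc2)cc1` differs from compound 3 in one place: 4-(dimethylamino)phenyl in place of 4-bromo-3-nitrophenyl on a double-bonded chain carbon bound to a double-bonded chain carbon. Among the measured compounds shown here, the one measured step that bears on this is an at least 100-fold lower number from compound 1 to compound 3 (2.00 log units; beyond the scatter), a large step running the opposite way, and compound 2 carries the same 4-(dimethylamino)phenyl as compound 4 while resting at a limit. A large rise in the number is therefore expected for compound 4, estimated as an at least 80-fold higher number from compound 3 to compound 4 (1.90 log units; beyond the scatter). Compound 4 is expected near 80000 nM, within 10000 nM to 300000 nM.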

Compound 4, concentration for 50% growth inhibition: 1000 nM
For compound 4 the middle estimate is 80-fold (1.90 log units) above the measured one, outside the stated range (below it).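

Carboxy in place of chloro on an aromatic carbon brings a large drop in the number (an at least 100-fold lower number from compound 2 to compound 4 (2.00 log units; beyond the scatter)), so 4-(dimethylamino)phenyl on a double-bonded chain carbon bound to a double-bonded chain carbon does not by itself rule out growth inhibition. With the carboxy kept, dimethylamino in place of carboxy also brings a large change (an at least 100-fold lower number from compound 1 to compound 4 (2.00 log units; beyond the scatter)), so this position accepts more than the 4-bromo-3-nitrophenyl group. Both steps start from a limit of the assay, and the size of the remaining step cannot be read (a number no lower from compound 3 to compound 4 (the limit leaves the size open)).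

Going by these compounds, whether an amide or a hydroxyl could replace the carboxy while keeping this growth inhibition stays open.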